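The compounds below may be only part of what the source reports. "The series", "measured", "known", "first", "only" and "open" are said of these compounds alone.

Compound 1 `Fc1cc2nc(-c3cncnc3)n(C3CC3)c2cc1F`: 22 nM in an assay on cells for inhibition of cytochrome P450 11B2, mitochondrial (Homo sapiens), read by HPLC, with a stated time of 90 min; on this read-out higher numbers stand for weaker inhibition and lower numbers for stronger inhibition
Compound 2 `Cc1ncncc1-c1nc2cc(F)c(F)cc2n1C1CC1`: 17 nM
Compound 3 `CNc1ncncc1-c1nc2cc(F)c(F)cc2n1C1CC1`: < 2 nM

The value for compound 3 is a limit of the measurement rather than a number, as the limit of < 2 nM in this assay, at which 1 of the 3 values shown sits, records. On the numbers shown, compound 3 stands as the strongest of the three: the steps of an at least 11-fold lower number from compound 1 to compound 3 (1.04 log units; beyond the scatter) and an at least 8.5-fold lower number from compound 2 to compound 3 (0.92 log units; beyond the scatter) both lie beyond the scatter, whereas the step of a 1.3-fold lower number from compound 1 to compound 2 (0.11 log units; within the scatter) lies within it.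

Compound 4 `CN(C)c1ncncc1-c1nc2cc(F)c(F)cc2n1C1CC1` differs from compound 3 by methyl in place of hydrogen on a nitrogen on an aromatic ring. Going by the values given here, no measured step adds a methyl to that nitrogen. The nearest comparison is a methyl added on an aromatic carbon, a 1.3-fold lower number from compound 1 to compound 2 (0.11 log units; within the scatter), and the methylamino group itself accounts for the large gain in an at least 11-fold lower number from compound 1 to compound 3 (1.04 log units; beyond the scatter). Since compound 3 already sits at the limit, a further gain could not be seen in this assay, and only a loss would register. For compound 4 the expected change is an at least 1.5-fold higher number from compound 3 to compound 4 (0.17 log units; that floor lies within the scatter) in this assay, a small weakening that may or may not exceed the scatter. The estimate for compound 4 in this assay is 3 nM, expected to fall between 1 nM and 12 nM.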

Compound 4, half-maximal inhibitory concentration: 29 nM
Compound 4: middle estimate off by 9.7-fold (0.99 log units), on the low side; the whole stated range lies below it.
By their numbers in this assay, from the lowest: compounds 2, 1 and 4 (each within the scatter of the next). At a limit, below all of these: compound 3.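

Adding one methyl to the nitrogen of the methylamino group, on the aromatic ring, has a large effect in this assay: an at least 14-fold higher number from compound 3 to compound 4 (1.16 log units; beyond the scatter), whereas a methyl on an aromatic carbon made little difference earlier, with a 1.3-fold lower number from compound 1 to compound 2 (0.11 log units; within the scatter). Compound 3 is recorded only as a limit of the assay, < 2 nM, and not as a number. The large gain seen with methylamino does not carry over to dimethylamino, as both a 1.3-fold higher number from compound 1 to compound 4 (0.12 log units; within the scatter) and a 1.7-fold higher number from compound 2 to compound 4 (0.23 log units; within the scatter) stay within the scatter, so compound 4 cannot be told apart from the compounds with hydrogen or methyl at this place on the core.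

The compounds shown cannot separate the loss of the hydrogen on this nitrogen from the presence of a second carbon group there; a plain amino group and an ethylamino group, each of which keeps a hydrogen on the nitrogen, would help to tell these apart. Going by these compounds, how far the true value of compound 3 lies past its limit also stays open, and with it the full size of the step to dimethylamino.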